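The source may report more compounds than this note shows. Statements on the series, on what has been measured and on what is new or still open speak of the compounds shown alone.

Compounds measured in an assay on cell membranes from spleen (Cavia porcellus) for binding affinity to leukotriene B4 receptor 1 (Homo sapiens); a lower number here means a stronger inhibitor, a higher number a weaker inhibitor:
compound 1 `O=C(O)CCCCOc1cc(-c2ccccc2)cc(-c2ccccc2)n1` gives 50 nM;
compound 2 `O=C(O)CCCCCOc1cc(-c2ccccc2)cc(-c2ccccc2)n1` gives 3 nM.

Compound 2 holds the lowest of the two numbers in this assay; the step of a 17-fold lower number from compound 1 to compound 2 (1.22 log units; beyond the scatter) separates it from compound 1. Compound 3 `N#CCCCCCOc1cc(-c2ccccc2)cc(-c2ccccc2)n1` differs from compound 2 by cyano in place of carboxy on a saturated chain carbon, five bonds along the chain from an oxygen on an aromatic ring. Within the data shown here, no measured step covers an exchange of this kind; the single step from compound 1 to compound 2 concerns chain length only, so the data give no direct guide. For compound 3 an expected value of 60 nM, within 6 nM to 600 nM, is estimated, corresponding to an expected step of a 20-fold higher number from compound 2 to compound 3 (1.30 log units; beyond the scatter).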

Compound 3, half-maximal inhibitory concentration: 700 nM
Estimate against measurement, compound 3: 12-fold (1.07 log units) below, outside the stated range (above it).
By their numbers in this assay, from the lowest: compound 2; then compound 1; then compound 3.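

Carboxy at this position, five bonds along the chain from an oxygen on an aromatic ring, does not tolerate exchange for cyano in this assay: the change gives a 230-fold higher number from compound 2 to compound 3 (2.37 log units; beyond the scatter). Compound 3 is also the weakest of the three, with a 14-fold higher number from compound 1 to compound 3 (1.15 log units; beyond the scatter), so the longer chain does not keep the number low once carboxy is gone. Nothing available here accounts for this loss.

As far as these compounds go, whether an amide or a tetrazole at the chain end would retain the low number remains open, as does the effect of a still longer chain ending in carboxy.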